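The source may hold more compounds than are shown below. What is called first, only, known or untested is meant among the compounds shown, and "the series" means these compounds.

Of the compounds shown here, two from this set have been measured, and a third is awaiting its number. Compound 1 `Cc1nc2c3ccccc3ccc2c2nc3c(ccc4ccccc43)c(-c3cc([N+](=O)[O-])ccc3N)c12` carries a nitro group and an amino group on the pendant ring, and in a functional assay on AGS cells (Homo sapiens) for cytotoxicity, read by MTT assay, with a stated time of 48 h (a higher number here means a weaker inhibitor, a lower number a stronger inhibitor), compound 1 gives 17800 nM. Compound 2 `Cc1nc2c3ccccc3ccc2c2nc3c(ccc4ccccc43)c(-c3ccccc3N)c12` differs from it only in the hydrogen that replaces the nitro group, and in this assay compound 2 gives 12100 nM. The step of a 1.5-fold lower number from compound 1 to compound 2 (0.17 log units; within the scatter) is the only one measured so far, and it does not part the two compounds. On the numbers shown, compound 2 stands with the lower of the two values, with compound 1 its nearest neighbour within the scatter.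

Compound 3 `Cc1nc2c3ccccc3ccc2c2nc3c(ccc4ccccc43)c(-c3ccc(O)cc3)c12` is the unmeasured member. Its change from compound 2 is 4-hydroxyphenyl in place of 2-aminophenyl on an aromatic carbon. Within the data shown here, no measured step involves this kind of swap; the one known step concerns the nitro group and lies within the scatter. With nothing to point in either direction, a step of a 1.0-fold lower number from compound 2 to compound 3 (0.00 log units; within the scatter) is expected, which is to say none beyond the scatter. Compound 3 is therefore estimated at 12000 nM, with a range from 5000 nM to 30000 nM.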

Compound 3, half-maximal inhibitory concentration: 14200 nM
Compound 3: middle estimate off by 1.2-fold (0.07 log units), on the low side; the range from low to high includes it.
By their numbers in this assay, from the lowest: compounds 2, 3 and 1 (each within the scatter of the next).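

In this assay, the swap on this aromatic carbon, opposite the ring nitrogen, alters both the group on the pendant ring and where it sits, with an amino group at the 2-position giving way to a hydroxy group at the 4-position, yet it gives a 1.2-fold higher number from compound 2 to compound 3 (0.07 log units; within the scatter) and so does not separate the two compounds. Set against the nitro-bearing group, 4-hydroxyphenyl in place of 2-amino-5-nitrophenyl gives a 1.3-fold lower number from compound 1 to compound 3 (0.10 log units; within the scatter) as its step, so all three pendant rings at this position now lie within the scatter of one another, and a hydroxy group in place of the amino group adds a second kind of change that leaves the reading unmoved. No separate measurement on these compounds bears on this flat result.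

The compounds shown leave open whether 2-hydroxyphenyl or 4-aminophenyl, which would pull apart the kind of group from its place on the ring, would read any differently. They also leave open whether a pendant ring bearing a carboxylic acid, or a longer alkyl chain at this carbon in place of the ring, would move the number beyond the scatter.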